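Trimming the ester from compound 2

This account rests on a few compounds, and the source may have more. Where it says the series, first, only, none or still open, it means among the compounds named here.

Measured so far:
compound 1 `COc1ccc(-c2nc(CCO)sc2-c2ccc(OC)cc2)cc1` — 100%
compound 2 `COC(=O)C(C)(C)c1nc(-c2ccc(OC)cc2)c(-c2ccc(OC)cc2)s1` — 100%

Both measured compounds share one core and differ only in a side chain on an aromatic carbon. In a functional assay on the whole organism for inhibition, with Cavia porcellus as the target, at a dose of 10 mg/kg by the oral route (a higher number here means a stronger effect of the compound at the dose given, a lower number a weaker effect), compound 1 gives 100%, and in the same test compound 2 gives 100%. The single measured step, no change at the digits printed from compound 1 to compound 2 (within the scatter), stands level at the digits shown, so compound 2 sits at the top of the scale alongside compound 1, with no ordering between them.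

Compound 3 `COc1ccc(-c2nc(C(C)C)sc2-c2ccc(OC)cc2)cc1` is the next step. The change is hydrogen in place of methoxycarbonyl on a saturated chain carbon bound to an aromatic carbon and two saturated chain carbons. Within the data shown here, only one measured step exists to guide this, and it exchanged one whole side chain for another without moving the read-out. The present change cuts part of that chain away instead, so the guidance is indirect. The expected step is a number 10 percentage points lower from compound 2 to compound 3 (within the scatter), small or none. Compound 3 is estimated at 90%, within a range from 60% to 100%.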

Compound 3, a percentage reported as inhibition, in the whole organism at one dose (the size of the read-out at that dose, not a potency): 100%
Beside the measured number, compound 3's estimate is 10 percentage points below it; the measured number falls inside the stated range.
By their numbers in this assay, from the lowest: compounds 1, 2 and 3 (each within the scatter of the next).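

In this assay, cutting 1-(methoxycarbonyl)-1-methylethyl back to isopropyl gives no change at the digits printed from compound 2 to compound 3 (within the scatter) and shows that the read-out at this dose does not depend on the methoxycarbonyl group. Isopropyl in place of 2-hydroxyethyl gives no change at the digits printed from compound 1 to compound 3 (within the scatter) and so a small side chain with neither the ester nor the hydroxyl matches both earlier compounds at this position. No outside measurement offers a reason for this sameness.

A read-out at a single dose is not a potency, so these results cannot show whether the three compounds would still read alike at a lower dose. Also open, from the compounds shown here alone, is how a carboxylic acid, an amine or a longer chain at this position would read in this assay and whether any such group would bring the number down.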